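The compounds below may be only part of what the source reports. "The series", "measured", "known", "first", "only" and "open" are said of these compounds alone.

Compounds measured in a functional assay on MDA-MB-231 cells (Homo sapiens) for inhibition, read by MTT assay, with a stated time of 72 h; on this read-out higher numbers stand for weaker inhibition and lower numbers for stronger inhibition:
compound 1, `CC1=C(C(C)CC(=O)OCCCOc2no[n+]([O-])c2S(=O)(=O)c2ccccc2)C(=O)c2c(O)cccc2C1=O`, 2420 nM;
compound 2, `CC1=C(CCC(=O)OCC(C)COc2no[n+]([O-])c2S(=O)(=O)c2ccccc2)C(=O)c2c(O)cccc2C1=O`, 2670 nM.

Compound 2 gives the highest of the two numbers in this assay, yet its value and that of compound 1 lie within the scatter of each other, so the two cannot be told apart on this read-out. Compound 3, `CC1=C(C(C)CC(=O)OCC(C)COc2no[n+]([O-])c2S(=O)(=O)c2ccccc2)C(=O)c2c(O)cccc2C1=O`, has not been measured. It differs from compound 2 in one place: methyl in place of hydrogen on a saturated chain carbon bound to a double-bonded ring carbon and a saturated chain carbon. Going by the values given here, no measured pair isolates this change, so no step size can be drawn from the data. The change from compound 2 to compound 3 is expected to give a 1.1-fold lower number from compound 2 to compound 3 (0.03 log units; within the scatter), a step that stays within the scatter. Compound 3 is therefore estimated at 2500 nM, with a range from 1200 nM to 5200 nM.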

Compound 3, half-maximal inhibitory concentration: 2110 nM
Beside the measured number, compound 3's estimate is 1.2-fold (0.07 log units) above it; the range from low to high includes it.
By their numbers in this assay, from the lowest: compounds 3, 1 and 2 (each within the scatter of the next).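

In this assay, methyl in place of hydrogen on a saturated chain carbon bound to a double-bonded ring carbon and a saturated chain carbon gives a 1.3-fold lower number from compound 2 to compound 3 (0.10 log units; within the scatter), while methyl in place of hydrogen on a saturated chain carbon bound to two saturated chain carbons gives a 1.1-fold lower number from compound 1 to compound 3 (0.06 log units; within the scatter). Both steps lie within the scatter, so at neither place can methyl be told apart from hydrogen on this read-out. Nothing at hand offers an explanation for this result.
As far as these compounds go, whether an ethyl group, a hydroxyl group or an amine on these chain carbons would give a step beyond the scatter remains open.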